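A few compounds are considered here, and "the series" means these few. Any claim that something is new, unique, unknown or untested is made for them only; others in the source may bear on it.

Compound 1 `O=C(Nc1cccc(-n2cc(-c3ccncc3)c(-c3ccc(Cl)c(O)c3)n2)c1)Nc1cccc(C(F)(F)F)c1` gives 32400 nM in a functional assay on LOX IMVI cells (Homo sapiens) for inhibition, read by sulforhodamine B assay, with a stated time of 48 h; a higher number here means that more compound is tolerated, a lower number that less compound is tolerated.
Compound 2 `COc1cc(-c2nn(-c3cccc(NC(=O)Nc4ccc(Cl)c(Cl)c4)c3)cc2-c2ccncc2)ccc1Cl` reaches only a limit of the assay in this assay, > 50000 nM.
Compound 3 `O=C(Nc1cccc(-n2cc(-c3ccncc3)c(-c3ccc(Cl)c(O)c3)n2)c1)Nc1ccc(Cl)c(Cl)c1` gives 15000 nM in this assay.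

Compound 2 and compound 3 share one core and differ in a single spot: methyl in place of hydrogen on an oxygen on an aromatic ring. That change alone gives an at least 3.3-fold lower number from compound 2 to compound 3 (0.52 log units; beyond the scatter). Only the lower bound of this step is known, because compound 2 sits at the limit of > 50000 nM in this assay, at which 1 of the 3 values shown sits.

Compound 1 and compound 3 differ in another single spot: 3-(trifluoromethyl)phenyl in place of 3,4-dichlorophenyl on an amide-type nitrogen. This change gives a 2.2-fold higher number from compound 3 to compound 1 (0.33 log units; beyond the scatter), so more compound is tolerated after it.

Compound 4 `COc1cc(-c2nn(-c3cccc(NC(=O)Nc4cccc(C(F)(F)F)c4)c3)cc2-c2ccncc2)ccc1Cl` has not yet been measured in this assay. It stands to compound 2 exactly as compound 1 stands to compound 3: 3-(trifluoromethyl)phenyl in place of 3,4-dichlorophenyl on an amide-type nitrogen. The place of the change reads the same word for word in both pairs, so this is the same change made a second time, now on the core that carries methoxy rather than hydroxy.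

Compound 2 already sits at a limit of the assay. The earlier step, a 2.2-fold higher number from compound 3 to compound 1 (0.33 log units; beyond the scatter), raised the number. Put together, the same change on compound 2 is expected to give a number at or past that limit. For compound 4 the expected step is a step that the limit leaves unreadable from compound 2 to compound 4. Compound 4 is therefore estimated at 90000 nM, most likely between 45000 nM and 200000 nM, with a real chance that the assay again reports only a limit.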

Compound 4, concentration lethal to 50% of the cells: 3460 nM
Compound 4: the middle estimate sits 26-fold (1.42 log units) above what was measured; the whole stated range lies above it.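

In this assay, putting 3-(trifluoromethyl)phenyl in place of 3,4-dichlorophenyl on the amide-type nitrogen of the methoxy core gives an at least 14-fold lower number from compound 2 to compound 4 (1.15 log units; beyond the scatter), so this change does not carry over from the hydroxy core: the same change on two cores in this assay, a 2.2-fold higher number (0.33 log units; beyond the scatter) from compound 3 to compound 1 and an at least 14-fold lower number (1.15 log units; beyond the scatter) from compound 2 to compound 4, at least 31-fold (1.49 log units) apart, beyond the scatter of two such steps

Seen from the other side of the same square of compounds, methyl in place of hydrogen on the oxygen gives a 9.4-fold lower number from compound 1 to compound 4 (0.97 log units; beyond the scatter), and the effect of that change likewise depends on the group at the other end of the molecule: the same change on two cores in this assay, an at least 3.3-fold lower number (0.52 log units; beyond the scatter) from compound 2 to compound 3 and a 9.4-fold higher number (0.97 log units; beyond the scatter) from compound 4 to compound 1, at least 31-fold (1.49 log units) apart, beyond the scatter of two such steps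

Compound 2 gives only a limit of the assay, > 50000 nM, so the direction of its step is known but not the full size; these four compounds show that the result of the swap on one core cannot be read across to the other here, but they do not show why, nor what the swap would do on any third core.

Going by these compounds, it stays open whether an ethyl group or an acetyl group on that oxygen would behave like the methyl or like the hydrogen. On these data alone, it also stays open whether a single chlorine or a nitrile on the phenyl ring, in place of the trifluoromethyl group, would follow the pattern of compound 1 or that of compound 4.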